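A few compounds are considered here, and "the series" means these few. Any claim that something is new, unique, unknown or untested is made for them only; others in the source may bear on it.

Series notes, side chain on the shared core. In a functional assay on MCF7 cells (Homo sapiens) for cytotoxicity, read by fluorescence, with a stated time of 72 h (on this read-out lower numbers stand for stronger inhibition and higher numbers for weaker inhibition), compound 1 `CC(C)c1n[nH]c2c(NCc3ccc(-c4ccccn4)cc3)nc(N3CCCCC3CCO)nc12` gives 133 nM, compound 2 `CC(C)c1n[nH]c2c(NCc3ccc(-c4ccccn4)cc3)nc(N[C@@H]3CCCC[C@H]3N)nc12` gives 295 nM and compound 3 `CC(C)c1n[nH]c2c(NCc3ccc(-c4ccccn4)cc3)nc(NCCN(C)C)nc12` gives 225 nM. Compound 3 is the second highest number of the three, but it stands within the scatter of both other compounds.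

The next comparison is compound 4 `COc1ccc(CNc2nc(NCc3ccc(-c4ccccn4)cc3)c3[nH]nc(C(C)C)c3n2)cc1`, which differs from compound 3 by 4-methoxyphenyl in place of (dimethylamino)methyl on a saturated chain carbon bound to a nitrogen on an aromatic ring. In words, this is 4-methoxyphenyl in place of (dimethylamino)methyl on a saturated chain carbon bound to a nitrogen on an aromatic ring.

Three measured side-chain steps bear on this change, though only indirectly, since none of them introduces 4-methoxyphenyl. They are a 2.2-fold higher number from compound 1 to compound 2 (0.35 log units; beyond the scatter), a 1.7-fold higher number from compound 1 to compound 3 (0.23 log units; within the scatter) and a 1.3-fold lower number from compound 2 to compound 3 (0.12 log units; within the scatter). Only the first lies beyond the scatter, and it is modest. Across these three compounds, side-chain changes therefore moved this assay very little. From the compounds shown here alone, the data give no direction for the new group, and how far these small steps carry over to it remains untested.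

The expected step is a 1.2-fold higher number from compound 3 to compound 4 (0.06 log units; within the scatter), which is no clear move beyond the scatter. For compound 4 the estimated value is 260 nM, with an expected range of 90 nM to 750 nM.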

Compound 4, half-maximal inhibitory concentration: 5300 nM
Compound 4: the middle estimate sits 20-fold (1.31 log units) below what was measured; measured number above the stated range.
By their numbers in this assay, from the lowest: compounds 1, 3 and 2 (each within the scatter of the next, the first and the last beyond it); then compound 4.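

In this assay this position proves far from indifferent to the side chain: 4-methoxyphenyl in place of (dimethylamino)methyl on a saturated chain carbon bound to a nitrogen on an aromatic ring gives a 24-fold higher number from compound 3 to compound 4 (1.37 log units; beyond the scatter) as a large step, whereas the earlier side-chain steps were modest or within the scatter. The other two comparisons agree in direction and class of size, with an 18-fold higher number from compound 2 to compound 4 (1.25 log units; beyond the scatter) and a 40-fold higher number from compound 1 to compound 4 (1.60 log units; beyond the scatter) in the same notes, so compound 4, with its (4-methoxybenzyl)amino side chain, stands well apart from compounds 1, 2 and 3. No evidence is at hand that accounts for this rise in the number.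

The compounds shown do not separate the contribution of the phenyl ring from that of its methoxy group, nor that of removing the dimethylamino group from that of introducing the ring. A plain benzyl, a 4-hydroxybenzyl or a 2-(4-methoxyphenyl)ethyl group at this position, or a 2-(dimethylamino)ethyl chain carrying a phenyl ring, would divide the step into those parts.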